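Working notes: a second methoxy onto compound 3

The source may report more compounds than this note shows. Statements on the series, on what has been measured and on what is new or still open speak of the compounds shown alone.

Measured compounds, all in a functional assay on the whole organism (strain albino) for inhibition, with Rattus norvegicus as the target, read by paw edema, with stated times of 30 min and 3 h, at a dose of 0.28 mmol/kg by the oral route; on this read-out higher numbers stand for more inhibition at the one dose given (going by the name of the read-out) and lower numbers for less inhibition:
- compound 1 `C/C(=N\O)c1ccc(NC(=O)CSc2nnc(-c3ccccc3)n2-c2ccccc2)cc1`: 63%
- compound 2 `CCn1c(SCC(=O)Nc2ccc(/C(C)=N/O)cc2)nnc1-c1ccc(OC)c(OC)c1`: 66%
- compound 3 `COc1ccc(-c2nnc(SCC(=O)Nc3ccc(/C(C)=N/O)cc3)n2-c2ccccc2)cc1`: 57%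

Among the measured compounds shown here, compound 3 stands lowest of the three numbers, but neither gap is large: the one measured single-point step, a number 6 percentage points lower from compound 1 to compound 3 (within the scatter), and the gap between compound 2 and compound 3 both lie within the scatter, so the three values are not separable.

Compound 4 `COc1ccc(-c2nnc(SCC(=O)Nc3ccc(/C(C)=N/O)cc3)n2-c2ccccc2)cc1OC` differs from compound 3 by methoxy in place of hydrogen on an aromatic carbon. For the measured compounds named here, only one measured step bears on this change, a number 6 percentage points lower from compound 1 to compound 3 (within the scatter), where a methoxy likewise entered on an aromatic carbon of the same ring; a step of that size gives no direction beyond the scatter. Compound 2 carries the same 3,4-dimethoxyphenyl but differs from compound 3 elsewhere as well, so its value is only a weak guide. Compound 4 is therefore expected near 60%, in a range from 47% to 73%. The step this estimate means is a number 3 percentage points higher from compound 3 to compound 4 (within the scatter), expected to stay within the scatter.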

Compound 4, a percentage reported as inhibition, in the whole organism at one dose (the size of the read-out at that dose, not a potency): 77%
Beside the measured number, compound 4's estimate is 17 percentage points below it; measured number outside the range, above it.
By their numbers in this assay, from the lowest: compounds 3, 1 and 2 (each within the scatter of the next); then compound 4.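

Among the compounds shown here, on the ring carrying the methoxy, a methoxy ortho to a methoxy group gives the first separation of this change from the scatter in this assay: the second methoxy gives a number 20 percentage points higher from compound 3 to compound 4 (beyond the scatter), whereas the single methoxy gave a number 6 percentage points lower from compound 1 to compound 3 (within the scatter). The full 3,4-dimethoxyphenyl also stands clear of the unsubstituted phenyl, at a number 14 percentage points higher from compound 1 to compound 4 (beyond the scatter), and with that group held constant, the aromatic nitrogen substituent matters too, at a number 11 percentage points higher from compound 2 to compound 4 (beyond the scatter). Nothing available explains why the second methoxy has this effect.

Open, going by these compounds, is whether the rise requires a methoxy at this place or would also follow with a hydroxy, an ethoxy or a chlorine there. Also open, on these data alone, is whether a 3-methoxyphenyl alone, without the other methoxy, gives the same rise.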